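Ortho substituent on the phenyl of the shared core

A few compounds are considered here, and "the series" means these few. Any claim that something is new, unique, unknown or untested is made for them only; others in the source may bear on it.

Compound 3 `CC1(C)N=C(N)N=C(N)N1c1ccccc1S` gives 6.86 in an assay on isolated protein for inhibition of Dihydrofolate reductase (Mus musculus), at pH 7.20 (on this read-out lower numbers stand for lower potency and higher numbers for higher potency (the scale is a negative logarithm)), the highest of the three numbers in hand. Compound 1 `CC1(C)N=C(N)N=C(N)N1c1ccccc1N` gives 3.41, and compound 2 `CSc1ccccc1N1C(N)=NC(N)=NC1(C)C` gives 2.48. The steps are large: a number 3.45 log units higher from compound 1 to compound 3 (beyond the scatter) and a number 4.38 log units higher from compound 2 to compound 3 (beyond the scatter), both beyond the scatter, while a number 0.93 log units lower from compound 1 to compound 2 (beyond the scatter) is modest.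

Compound 4 `CC1(C)N=C(N)N=C(N)N1c1ccccc1F` is not yet measured. Its change from compound 3 is fluoro in place of sulfanyl on an aromatic carbon. Among the compounds with values here, no measured step tests fluoro directly; the steps into compound 3 show that replacing sulfanyl by another group has so far cost a great deal, so a large drop is expected for compound 4, a number 2.86 log units lower from compound 3 to compound 4 (beyond the scatter). The estimate for compound 4 is 4, within 2.8 to 5.5.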

Compound 4, logarithm of the reciprocal of the active concentration, log(1/C): 4.39
Compound 4: middle estimate off by 0.39 log units, on the low side; the range from low to high includes it.
By their numbers in this assay, from the lowest: compound 2; then compound 1; then compound 4; then compound 3.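

Fluoro does not match sulfanyl, with a number 2.47 log units lower from compound 3 to compound 4 (beyond the scatter) at this position, but it outranks both other groups, with a number 0.98 log units higher from compound 1 to compound 4 (beyond the scatter) and with a number 1.91 log units higher from compound 2 to compound 4 (beyond the scatter) as well. Leaving sulfanyl therefore does not always cost the same: the four groups fall in the order methylsulfanyl, amino, fluoro, sulfanyl, with each neighbouring gap beyond the scatter.

As far as these compounds go, whether chloro, hydroxyl or ethylsulfanyl would come closer to sulfanyl remains open. Nothing available accounts for the size of these steps.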